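Anilino in place of oxan-4-ylamino on the core

A few compounds are considered here, and "the series" means these few. Any claim that something is new, unique, unknown or untested is made for them only; others in the source may bear on it.

Compound 1 `Cc1cc(-c2cnn3c(NCC4CCOCC4)nc(NC4CCOCC4)nc23)ccc1C(=O)NC1CC1` stands with the highest number of the two measured in a functional assay on MDA-MB-231 cells (Homo sapiens) for antiproliferative activity; a lower number here means a stronger inhibitor of growth, a higher number a weaker inhibitor of growth; compound 1 gives 540 nM. Compound 2 `O=C(NC1CC1)c1ccc(-c2cnn3c(NCC4CCOCC4)nc(Oc4ccccc4)nc23)cc1` differs from compound 1 in more than one place, and in this assay compound 2 gives 350 nM, a gap to compound 1 within the scatter. Compound 3 `Cc1cc(-c2cnn3c(NCC4CCOCC4)nc(Nc4ccccc4)nc23)ccc1C(=O)NC1CC1` differs from compound 1 by phenyl in place of oxan-4-yl on a nitrogen on an aromatic ring. For the measured compounds named here, no step between measured compounds covers this change alone. The expected step of a 1.4-fold lower number from compound 1 to compound 3 (0.15 log units; within the scatter) is small, with a slight lean toward a lower number, not beyond the scatter. Compound 3 is estimated at 380 nM, within a range from 130 nM to 1100 nM.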

Compound 3, concentration for 50% growth inhibition: 1200 nM
For compound 3 the middle estimate is 3.2-fold (0.50 log units) below the measured one; the whole stated range lies below it.
By their numbers in this assay, from the lowest: compounds 2 and 1 (each within the scatter of the next); then compound 3.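

At the nitrogen on an aromatic ring, phenyl in place of oxan-4-yl gives a 2.2-fold higher number from compound 1 to compound 3 (0.35 log units; beyond the scatter) in this assay. For the compounds shown here, this is the first single-change reading, and it shows that this position is sensitive to the change: anilino does not hold the level of (oxan-4-yl)amino, although the step is modest. Nothing measured here bears on the reason for this step.

On these data alone, whether cyclohexylamino or benzylamino at this nitrogen would sit nearer compound 1 or compound 3 remains open. Compound 2 differs from compound 3 in more than one place, so it settles nothing about this change.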